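A few compounds are considered here, and "the series" means these few. Any claim that something is new, unique, unknown or untested is made for them only; others in the source may bear on it.

Measured so far in a functional assay on A549 cells (Homo sapiens) for cytotoxicity, read by MTT assay, with a stated time of 72 h; on this read-out lower numbers stand for stronger inhibition and higher numbers for weaker inhibition:
compound 1, `COc1ccc(/C=N/NC(=O)Nc2ccc(Oc3ccnc(-c4nncn4CCN(C)C)c3)c(F)c2)c(OC)c1`, gives 2820 nM.
compound 2, `CN(C)CCn1cnnc1-c1cc(Oc2ccc(NC(=O)N/N=C/c3ccc(O)c(F)c3)cc2F)ccn1`, gives 13400 nM.
compound 3, `CN(C)CCn1cnnc1-c1cc(Oc2ccc(NC(=O)N/N=C/c3ccc(F)cc3Cl)cc2F)ccn1`, gives 1120 nM.

Compound 1 sits second highest of the three numbers, between compound 3 and compound 2. Compound 4, `COc1cc(/C=N/NC(=O)Nc2ccc(Oc3ccnc(-c4nncn4CCN(C)C)c3)c(F)c2)ccc1O`, is still unmeasured; against compound 1 it shows (4-hydroxy-3-methoxyphenyl in place of 2,4-dimethoxyphenyl on a carbon with a double bond to nitrogen). The step that bears most directly on this change is the one in this assay from compound 1 to compound 2, where a hydroxy-bearing phenyl also entered on the carbon with a double bond to nitrogen and gave a 4.8-fold higher number from compound 1 to compound 2 (0.68 log units; beyond the scatter). The contrasting step, a 2.5-fold lower number from compound 1 to compound 3 (0.40 log units; beyond the scatter), and the wide gap a 12-fold lower number from compound 2 to compound 3 (1.08 log units; beyond the scatter) show that the aryl group on this carbon moves the number well beyond the scatter in both directions. Compound 4 keeps one methoxy group while adding the hydroxy group, so a rise in the number is expected, likely smaller than that seen for compound 2; the expected step is a 2.0-fold higher number from compound 1 to compound 4 (0.29 log units; within the scatter). Compound 4 is therefore estimated at 5500 nM, with a range from 2500 nM to 13000 nM.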

Compound 4, half-maximal inhibitory concentration: > 100000 nM
Compound 4: only a limit was reported; the forecaster's own chance of this, stated with the estimate: 5%; middle value at least 18-fold (1.25 log units) away from the limit.
By their numbers in this assay, from the lowest: compound 3; then compound 1; then compound 2. At a limit, above all of these: compound 4.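

In this assay compound 4 stands at a limit and not at a number: the limit of > 100000 nM in this assay, at which 1 of the 4 values shown sits. Among the compounds shown here, the aryl group on the carbon with a double bond to nitrogen can therefore shift the read-out further than the earlier compounds showed, with an at least 35-fold higher number from compound 1 to compound 4 (1.54 log units; beyond the scatter) and an at least 89-fold higher number from compound 3 to compound 4 (1.95 log units; beyond the scatter). Among the two aryl groups that carry a hydroxy group, methoxy in place of fluoro on an aromatic carbon still gives an at least 7.4-fold higher number from compound 2 to compound 4 (0.87 log units; beyond the scatter), so the presence of a hydroxy group does not alone set the number.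

The compounds shown do not separate the effect of the hydroxy group from that of where the methoxy group sits on the ring. From the compounds shown here alone, whether an amine or a carboxylic acid in place of that hydroxy group would keep the number this high also remains open.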